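The compounds below may be only part of what the source reports. "The series", "measured", "known", "first", "only" and "open" are said of these compounds alone.

The set shares a single amide-linked core, seen first in compound 1 `CCNC(=O)c1cc(Oc2ccc(NC(=O)c3cc4cccnc4n(-c4ccccc4)c3=O)cc2)ccn1`. In a functional assay on NCI-H460 cells (Homo sapiens) for antiproliferative activity, read by MTT assay, with a stated time of 72 h (a higher number here means a weaker inhibitor, a lower number a stronger inhibitor), compound 1 gives 1120 nM. Among the compounds with values here, compound 2 `CCNC(=O)c1cc(Oc2ccc(NC(=O)c3cc4cccnc4n(-c4ccc(Br)cc4)c3=O)cc2)ccn1` carries a bromine on the outer phenyl ring; in this assay compound 2 gives "not determined" (no result reported), so no number is available for it, and the only measured anchor remains compound 1. Compound 3 `CCNC(=O)c1cc(Oc2ccc(NC(=O)c3cc4cccnc4n(-c4ccc(OC)cc4)c3=O)cc2)ccn1` differs from compound 2 by methoxy in place of bromo on an aromatic carbon. Within the data shown here, no measured pair shows what that exchange does, and compound 2 itself provides no value to step from, so the expected change from compound 2 to compound 3 in this assay cannot be sized from the data; the nearest guide is compound 1, which carries an unsubstituted phenyl at the same position. On that basis compound 3 is expected to land close to compound 1, with an estimated value of 1000 nM in this assay, and a plausible range from 300 nM to 4000 nM.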

Compound 3, half-maximal inhibitory concentration: 1720 nM
For compound 3 the middle estimate is 1.7-fold (0.24 log units) below the measured one, within the range that was stated.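

Within the data shown here, compound 3 gives the first readable step at this position, the place on the outer phenyl ring para to a large group: in this assay, methoxy in place of hydrogen gives a 1.5-fold higher number from compound 1 to compound 3 (0.19 log units; within the scatter). Among these compounds, the 4-methoxyphenyl and unsubstituted phenyl forms therefore cannot be told apart in this assay, so this one substituent at this position brings no change that the data can resolve, whereas the earlier compounds offered no comparison here at all. The step from compound 2 to compound 3 cannot be read, as compound 2 has no number, and no supporting data bear on why the methoxy exchange behaves as it does.

On these data alone, with only hydrogen and methoxy compared, it remains open whether any group at this position can move the number beyond the scatter, for instance an amine, a carboxylic acid or a longer alkoxy chain such as butoxy. The effect of bromo also stays unknown, and the compounds shown say nothing about changes elsewhere on the shared core, such as replacing the ethyl group on the outer amide with a longer chain.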